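The source may report more compounds than this note shows. Statements on the series, on what has been measured and on what is new or still open speak of the compounds shown alone.

Measured in an assay on Sf9 cells for inhibition of histone deacetylase 11 (Homo sapiens), read by fluorescence, tested at 0.5 uM; a higher number here means more inhibition at the concentration tested (going by the name of the read-out), a lower number less inhibition:
compound 1, `O=C(NO)c1cccc(-c2cn([C@H]3C[C@@H](C(=O)O)N(CCCc4ccccc4)C3)nn2)c1`, gives < 10%, which is a limit of the assay and not a number.
compound 2, `O=C(/C=C/c1cn([C@H]2C[C@@H](C(=O)O)N(CCCc3ccccc3)C2)nn1)NO`, gives 29%.

For the measured compounds named here, compound 2 thus holds the only number in this assay; the other value is a limit. Compound 3, `O=C(NO)c1ccc(-c2cn([C@H]3C[C@@H](C(=O)O)N(CCCc4ccccc4)C3)nn2)cc1`, is the unmeasured member of the set. It differs from compound 2 by 4-(hydroxycarbamoyl)phenyl in place of 2-(hydroxycarbamoyl)ethenyl on an aromatic carbon. Going by the values given here, only one measured step bears on this change, and it runs in the opposite sense: a number at least 19 percentage points higher from compound 1 to compound 2 (beyond the scatter). That step removed a hydroxycarbamoyl-bearing phenyl in favour of the ethenyl chain and raised inhibition beyond the scatter; the step to compound 3 puts a phenyl back, now as 4-(hydroxycarbamoyl)phenyl rather than the 3-(hydroxycarbamoyl)phenyl of compound 1, so it is not an exact reversal. A fall from compound 2 in this assay is therefore expected, with a real chance of returning to the limit where compound 1 sits, (the limit of < 10% in this assay, at which 1 of the 2 values shown sits). Compound 3 is expected to give 15%, ranging from 5% to 28%. This expectation corresponds to the estimated step of a number 14 percentage points lower from compound 2 to compound 3 (beyond the scatter).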

Compound 3, a percentage reported as inhibition, at one concentration (the size of the read-out at that concentration, not a potency): 14%
For compound 3 the middle estimate is 1 percentage points above the measured one; measured number inside the range.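

In this assay, for the compounds shown here, 4-(hydroxycarbamoyl)phenyl in place of 2-(hydroxycarbamoyl)ethenyl on the aromatic carbon of the five-membered ring gives a number 15 percentage points lower from compound 2 to compound 3 (beyond the scatter), so compound 2 now stands clear of the scatter against both phenyl compounds, not only the one with the 3-(hydroxycarbamoyl)phenyl group. Between the two phenyl groups the reading is a number at least 4 percentage points higher from compound 1 to compound 3 (that floor lies within the scatter), which leaves 3-(hydroxycarbamoyl)phenyl and 4-(hydroxycarbamoyl)phenyl unseparated in this series. The value for compound 1 is a limit of the assay and not a number, and this restricts that comparison to a floor: the limit of < 10% in this assay, at which 1 of the 3 values shown sits.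

Still open, as far as these compounds go, is whether the advantage of compound 2 belongs to the ethenyl chain itself or would carry over to a saturated ethylene link or a longer chain ending in the same hydroxycarbamoyl group. From the compounds shown here alone, the three compounds also share the same carboxylic acid and phenylpropyl group on the core, so how an amide or ester at the acid position would shift these readings remains unknown.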